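A few compounds are considered here, and "the series" means these few. Any claim that something is new, unique, unknown or untested is made for them only; others in the source may bear on it.

Within the data shown here, compound 3 `C[C@H](NC(=O)c1c(C2CC2)nnn1Cc1ccc(C(F)(F)F)cc1)c1ccc(C(=O)O)cc1` stands alone in this set as the one compound with a number in a functional assay on CHO cells for antagonist activity at prostaglandin E2 receptor EP4 subtype (Homo sapiens), read by calcium flux, with a stated time of 15 min; a higher number here means a weaker inhibitor, a lower number a stronger inhibitor: in this assay compound 3 gives 52.1 nM. Compound 1 `C[C@H](NC(=O)c1cn(Cc2ccc(C(F)(F)F)cc2)nn1)c1ccc(C(=O)O)cc1` reaches only a limit of the assay; in this assay compound 1 gives > 10000 nM. Compound 2 `CCCc1c(C(=O)N[C@@H](C)c2ccc(C(=O)O)cc2)nnn1Cc1ccc(C(F)(F)F)cc1` likewise stops at a limit; in this assay compound 2 gives > 10000 nM. Among the measured compounds shown here, the single measured step, a step that the two limits leave unreadable from compound 1 to compound 2, cannot be sized because of the limit of > 10000 nM in this assay, at which 2 of the 3 values shown sit. Compound 4 `C=CCc1nnn(Cc2ccc(C(F)(F)F)cc2)c1C(=O)N[C@@H](C)c1ccc(C(=O)O)cc1` differs from compound 3 by allyl in place of cyclopropyl on an aromatic carbon. For the measured compounds named here, no measured step covers this exact change, since cyclopropyl appears only in compound 3 and propyl only in compound 2. Going by the values given here, the allyl group of compound 4 is an open chain of the same length as propyl, and compound 2 with that propyl gives only a limit, whereas compound 3 with cyclopropyl gives the sole number. On that basis the change from cyclopropyl to allyl is expected to lose potency, with a real chance that this assay again reports only a limit. The expected step is a 12-fold higher number from compound 3 to compound 4 (1.06 log units; beyond the scatter). Compound 4 is therefore estimated to give about 600 nM in this assay, within a range from 100 nM to 5000 nM.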

Compound 4, half-maximal inhibitory concentration: > 1000 nM
Compound 4: only a limit was reported (the forecaster's own chance of this, stated with the estimate: 25%); middle value at least 1.6-fold (0.22 log units) from the limit.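

Among these compounds, at this aromatic carbon, the earlier compounds offered no step that could be read, whereas allyl in place of cyclopropyl now gives an at least 19-fold higher number from compound 3 to compound 4 (1.28 log units; beyond the scatter) in this assay. Among the compounds shown here, the two groups have the same atoms, joined differently: cyclopropyl is a three-membered ring, and allyl has no ring and carries a double bond, so how those atoms are joined is the only difference between compound 3 and compound 4. Among the compounds shown, cyclopropyl in compound 3 is now the only group at this carbon that gives a number, while hydrogen in compound 1, propyl in compound 2 and allyl in compound 4 all end at limits of the assay.

From the compounds shown here alone, how large the step really is stays open, and the step from compound 1 to compound 2 cannot be read either, because these compounds give only limits rather than numbers: the limit of > 10000 nM in this assay, at which 2 of the 4 values shown sit. Whether a cyclobutyl, isopropyl or methyl group at this carbon would give a number in this assay, and so whether the ring itself matters, also remains open.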